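Pyrimidin-2-yl on the piperazine nitrogen: a step from compound 1

The source may hold more compounds than are shown below. What is called first, only, known or untested is meant among the compounds shown, and "the series" means these compounds.

Measured compounds:
compound 1, `O=C1c2ccccc2S(=O)(=O)N1CCCCCCN1CCN(c2cccc(Cl)c2)CC1`: 233 nM
compound 2, `O=C1c2ccccc2S(=O)(=O)N1CCCCCCN1CCN(c2ccccn2)CC1`: 552 nM

Both values come from an ADME assay on HEK293 cells for displacement of a labelled ligand from 5-hydroxytryptamine receptor 7 (Homo sapiens), read by radioligand binding, with a stated time of 1 h; on this read-out higher numbers stand for weaker inhibition and lower numbers for stronger inhibition. Compound 1 has the lowest of the two numbers; its nearest neighbour is compound 2, which shows a 2.4-fold higher number from compound 1 to compound 2 (0.37 log units; beyond the scatter).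

Compound 3, `O=C1c2ccccc2S(=O)(=O)N1CCCCCCN1CCN(c2ncccn2)CC1`, has not been measured. It differs from compound 1 in one place: pyrimidin-2-yl in place of 3-chlorophenyl on an amine nitrogen in a ring.

Among the compounds with values here, only one measured step bears on this change, the one from compound 1 to compound 2, in which a pyridin-2-yl also replaces the 3-chlorophenyl and gives a 2.4-fold higher number from compound 1 to compound 2 (0.37 log units; beyond the scatter). A pyrimidin-2-yl is a second aromatic ring with hetero atoms in the same place, so a step of about that size and direction, or somewhat larger, is expected for compound 3: a 3.2-fold higher number from compound 1 to compound 3 (0.51 log units; beyond the scatter). Compound 3 is therefore estimated at 750 nM, in a range from 250 nM to 2200 nM.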

Compound 3, inhibition constant: 35 nM
The estimate for compound 3 lay 21-fold (1.33 log units) above the measured number, outside the stated range (below it).
By their numbers in this assay, from the lowest: compound 3; then compound 1; then compound 2.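

In this assay, pyrimidin-2-yl in place of 3-chlorophenyl on the amine nitrogen in a ring gives a 6.7-fold lower number from compound 1 to compound 3 (0.82 log units; beyond the scatter), the opposite direction to the earlier pyridin-2-yl change, so two heteroaromatic replacements at this position do not act alike. The change between those two rings alone gives a 16-fold lower number from compound 2 to compound 3 (1.20 log units; beyond the scatter), a larger step than either has from 3-chlorophenyl, which shows that this position responds strongly to the identity of the ring and not merely to the loss of 3-chlorophenyl. Nothing available accounts for this difference between the two rings.

Going by these compounds, it remains open whether a pyrazin-2-yl or a pyrimidin-5-yl on the same nitrogen would follow pyrimidin-2-yl or pyridin-2-yl. On these data alone, it is also open whether the order of these three compounds would hold with a shorter chain to the core.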